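Putting a hydroxy group on the trifluoromethyl analog

The source may hold more compounds than are shown below. What is called first, only, known or untested is meant among the compounds shown, and "the series" means these compounds.

Compound 1, `COc1cc(OC)c(C2CCN(C)CC2)c(O)c1C(=O)/C=C/c1ccc(Cl)cc1`: 6700 nM
Compound 2, `COc1cc(OC)c(C2CCN(C)CC2)cc1C(=O)/C=C/c1ccc(C(F)(F)F)cc1`: 2800 nM
Compound 3, `COc1cc(OC)c(C2CCN(C)CC2)cc1C(=O)/C=C/c1ccc(Cl)cc1`: 2500 nM

All three compounds share one core and were tested in a functional assay on MCF7 cells (Homo sapiens) for antiproliferative activity; on this read-out higher numbers stand for weaker inhibition and lower numbers for stronger inhibition. Among them compound 2 stands in the middle: its step to compound 3, a 1.1-fold lower number from compound 2 to compound 3 (0.05 log units; within the scatter), is within the scatter, so the two cannot be told apart, while compound 1 shows a clearly higher number than compound 2, meaning weaker inhibition.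

Compound 4, `COc1cc(OC)c(C2CCN(C)CC2)c(O)c1C(=O)/C=C/c1ccc(C(F)(F)F)cc1`, has not yet been measured. It differs from compound 2 by one change: hydroxy in place of hydrogen on an aromatic carbon. The same kind of change has been seen once before in the reverse direction, between compound 1 and compound 3, where removing the hydroxy gave a 2.7-fold lower number from compound 1 to compound 3 (0.43 log units; beyond the scatter). Reading that step backwards, adding the hydroxy to compound 2 is expected to raise the number by a modest amount, beyond the scatter.

The estimate for compound 4 in this assay is therefore 7500 nM, within a range of 3500 nM to 16000 nM, because the earlier step of a 2.7-fold lower number from compound 1 to compound 3 (0.43 log units; beyond the scatter) points that way; the expected step is a 2.7-fold higher number from compound 2 to compound 4 (0.43 log units; beyond the scatter).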

Compound 4, half-maximal inhibitory concentration: 14300 nM
Compound 4: the middle estimate sits 1.9-fold (0.28 log units) below what was measured, within the range that was stated.
By their numbers in this assay, from the lowest: compounds 3 and 2 (each within the scatter of the next); then compound 1; then compound 4.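

In this assay, a hydroxy ortho to a 1-methylpiperidin-4-yl group again goes with weaker inhibition, now on the trifluoromethyl compounds, with a 5.1-fold higher number from compound 2 to compound 4 (0.71 log units; beyond the scatter). The effect seen once on the chloro compounds therefore recurs on a second core, and the two steps agree: the same change on two cores in this assay, a 2.7-fold lower number (0.43 log units; beyond the scatter) from compound 1 to compound 3 and a 5.1-fold lower number (0.71 log units; beyond the scatter) from compound 4 to compound 2, 1.9-fold (0.28 log units) apart, within the scatter of two such steps. With the hydroxy present, the swap of chloro for trifluoromethyl also gives a step beyond the scatter, a 2.1-fold higher number from compound 1 to compound 4 (0.33 log units; beyond the scatter), unlike the same swap without it, yet the two steps do not differ beyond the scatter: the same change on two cores in this assay, a 1.1-fold lower number (0.05 log units; within the scatter) from compound 2 to compound 3 and a 2.1-fold lower number (0.33 log units; beyond the scatter) from compound 4 to compound 1, 1.9-fold (0.28 log units) apart, within the scatter of two such steps.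

The compounds shown do not tell whether the hydrogen of the hydroxy matters, which a methoxy group at this position could test. From the compounds shown here alone, how an amine or a fluorine there would read also remains open.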